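This account rests on a few compounds, and the source may have more. Where it says the series, first, only, none or still open, it means among the compounds named here.

In a functional assay on MV4-11 cells (Homo sapiens) for antiproliferative activity, read by resazurin assay, with a stated time of 72 h (on this read-out lower numbers stand for stronger inhibition of growth and higher numbers for weaker inhibition of growth), compound 1 (`CC(=O)N1CCN(c2ccc(Nc3nccc(-c4c[nH]c5cccnc45)n3)cc2)CC1`) gives 420 nM, compound 2 (`CC(=O)N1CCN(c2ccc(Nc3nccc(-c4nn(C)c5ccccc45)n3)cc2)CC1`) gives 181 nM and compound 3 (`CC(=O)N1CCN(c2ccc(Nc3nccc(-c4cn(C)c5ccccc45)n3)cc2)CC1`) gives 252 nM. Compound 3 lies within the scatter of both others; only a 2.3-fold lower number from compound 1 to compound 2 (0.37 log units; beyond the scatter) goes beyond it. The step under study leads to compound 4 (`CC(=O)N1CCN(c2ccc(Nc3nccc(-c4n[nH]c5ccccc45)n3)cc2)CC1`): 1H-indazol-3-yl in place of 1-methyl-1H-indol-3-yl on an aromatic carbon, with 1H-indazol-3-yl in place of 1-methyl-1H-indol-3-yl. Going by the values given here, no measured pair isolates loss of the methyl group. The nearest evidence, a 1.4-fold higher number from compound 2 to compound 3 (0.14 log units; within the scatter), stays within the scatter, as does a 1.7-fold lower number from compound 1 to compound 3 (0.22 log units; within the scatter). In this assay, no step beyond the scatter is expected, and the estimated step is a 1.2-fold higher number from compound 3 to compound 4 (0.08 log units; within the scatter). Compound 4 is expected at 300 nM, with an estimated range of 120 nM to 750 nM.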

Compound 4, concentration for 50% growth inhibition: 346 nM
Beside the measured number, compound 4's estimate is 1.2-fold (0.06 log units) below it, and the stated range covers the measured number.
By their numbers in this assay, from the lowest: compounds 2, 3, 4 and 1 (each within the scatter of the next, the first and the last beyond it).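

In this assay, going by these compounds alone, hydrogen in place of methyl on an aromatic nitrogen (a 1.9-fold higher number from compound 2 to compound 4 (0.28 log units; within the scatter)) isolates loss of the methyl group for the first time, and the step stays within the scatter. 1H-indazol-3-yl in place of 1-methyl-1H-indol-3-yl (a 1.4-fold higher number from compound 3 to compound 4 (0.14 log units; within the scatter)) and in place of the group on compound 1 (a 1.2-fold lower number from compound 1 to compound 4 (0.08 log units; within the scatter)) also stays within the scatter, so the hydrogen-bond donor entering with compound 4 brings no step beyond it. Nothing available gives a reason for these steps.

Open, going by these compounds, is whether an ethyl group, a 2-hydroxyethyl chain or a longer chain ending in an amine on that aromatic nitrogen would move the number beyond the scatter.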